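From bromo to methoxy on an aromatic ring

The source may report more compounds than this note shows. Statements on the series, on what has been measured and on what is new or still open speak of the compounds shown alone.

In a functional assay on MCF7 cells (Homo sapiens) for inhibition, read by sulforhodamine B assay (a higher number here means a weaker inhibitor, a lower number a stronger inhibitor), compound 1 `O=C1C(Nc2ccc(Br)cc2)=CC(=O)c2c1nc1n2[C@H]2OC[C@@H](O)[C@H]2OC1` gives 4330 nM and compound 2 `O=C1C=C(Nc2ccccc2F)C(=O)c2c1nc1n2[C@H]2OC[C@@H](O)[C@H]2OC1` gives 3640 nM, two values within the usual scatter of each other. Compound 3 `O=C1C=C(NC2CCCC2)C(=O)c2c1nc1n2[C@H]2OC[C@@H](O)[C@H]2OC1` gives > 16000 nM, which is a limit of the assay and not a number.

Compound 4 `COc1ccc(NC2=CC(=O)c3c(nc4n3[C@H]3OC[C@@H](O)[C@H]3OC4)C2=O)cc1` differs from compound 1 by methoxy in place of bromo on an aromatic carbon, para to a large group (methoxy in place of bromo on an aromatic carbon). Among the measured compounds shown here, no measured step makes this same change. For the measured compounds named here, the only measured step, an at least 4.3-fold higher number from compound 2 to compound 3 (0.64 log units; beyond the scatter), put cyclopentyl in place of 2-fluorophenyl on an amine nitrogen. That swap replaced the whole aromatic ring, whereas compound 4 keeps its ring, so the step offers only a loose guide. Starting from compound 1 at 4330 nM, no step beyond the scatter is therefore expected in this assay. The estimated change is a 1.1-fold lower number from compound 1 to compound 4 (0.03 log units; within the scatter). For compound 4 the expected value is 4000 nM, with an estimated range from 1500 nM to 11000 nM.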

Compound 4, half-maximal inhibitory concentration: 4470 nM
Compound 4: middle estimate off by 1.1-fold (0.05 log units), on the low side, and the stated range covers the measured number.
By their numbers in this assay, from the lowest: compounds 2, 1 and 4 (each within the scatter of the next). At a limit, above all of these: compound 3.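

Unlike the earlier step, which replaced the whole aromatic ring, this change touches only the group on the ring, para to a large group. In this assay the result is a 1.0-fold higher number from compound 1 to compound 4 (0.01 log units; within the scatter) and stays within the scatter, so bromo and methoxy cannot be told apart at this position, even though methoxy brings a hydrogen-bond acceptor that bromo lacks. None of the information given here bears on why the two groups read alike.

This reading rests on a single pair of compounds, in one assay and at one position on the ring. From the compounds shown here alone, whether an amine, a carboxylic acid or a longer chain at the same position would also stay within the scatter of compound 1 remains open, as does the effect of moving methoxy elsewhere on the ring.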